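The source may hold more compounds than are shown below. What is called first, only, known or untested is meant among the compounds shown, and "the series" means these compounds.

Of the compounds shown here, three that share one core have been measured in a functional assay (aorta) for inhibition, with Rattus norvegicus as the target; a lower number here means a stronger inhibitor, a higher number a weaker inhibitor. Compound 1 (`C/N=C(\S)[C@]1(c2ccc(Cl)nc2)CCCC[S+]1[O-]`) gives 300 nM, the lowest number of the three, and compound 2 (`C/N=C(\S)[C@]1(c2ccns2)CCCC[S+]1[O-]`) gives 7000 nM, the highest. Compound 3 (`C/N=C(\S)[C@]1(c2cccc(C(F)(F)F)c2)CCCC[S+]1[O-]`) gives 800 nM, which makes it the second highest. Its gaps to both of the others lie beyond the usual scatter, and compound 1 is its nearer neighbour.

Compound 4 (`C/N=C(\S)[C@]1(c2ccccc2)CCCC[S+]1[O-]`) has not yet been measured. It differs from compound 3 at a single place: hydrogen in place of trifluoromethyl on an aromatic carbon, with hydrogen in place of trifluoromethyl on an aromatic carbon. For the measured compounds named here, no two measured compounds differ in only one place, so the data give no direct measure of this change. Going by the values given here, the only hint is thin: the one measured compound with no substituent on its aromatic ring, compound 2 at 7000 nM, also has the highest number, although its ring differs as well. In this assay the expected change is therefore a moderate one toward a weaker inhibitor, estimated as a 3.1-fold higher number from compound 3 to compound 4 (0.49 log units; beyond the scatter). The estimate for compound 4 is 2500 nM, with an expected range of 800 nM to 8000 nM.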

Compound 4, concentration for 90% inhibition: 9500 nM
Beside the measured number, compound 4's estimate is 3.8-fold (0.58 log units) below it; the whole stated range lies below it.
By their numbers in this assay, from the lowest: compound 1; then compound 3; then compounds 2 and 4 (each within the scatter of the next).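

In this assay, putting hydrogen in place of trifluoromethyl gives a 12-fold higher number from compound 3 to compound 4 (1.07 log units; beyond the scatter), the first direct measure of a single change among these compounds, and a large one. It shows that this place, on an aromatic carbon meta to a large group, is not indifferent: with the rest of the structure unchanged, the inhibitor carrying trifluoromethyl there is much stronger than the one carrying only hydrogen. The finding rests on this one pair, so it applies only to this change on this six-membered aromatic ring of carbon only, and not to the other rings in the set. Nothing measured here accounts for the size of the step.

On these data alone, it remains open whether the stronger inhibition belongs to trifluoromethyl in particular or would come with almost any group at this place, a question that a methyl, a methoxy or a nitrile there would help to settle. The compounds shown also leave open whether an amine or a carboxylic acid at the same place would be tolerated at all.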